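Bromo in place of fluoro: a step still to measure

A few compounds are considered here, and "the series" means these few. Any claim that something is new, unique, unknown or untested is made for them only; others in the source may bear on it.

Compound 1 `COc1ccc(-c2nnc(SCCCN3CCN(c4nc5ccccc5o4)CC3)o2)cc1` gives 93500 nM
Compound 2 `Fc1ccc(-c2nnc(SCCCN3CCN(c4nc5ccccc5o4)CC3)o2)cc1` gives 75700 nM
Compound 3 `Brc1ccc(-c2nnc(SCCCN3CCN(c4nc5ccccc5o4)CC3)o2)cc1` has no measurement yet

For the measured compounds named here, in a functional assay on A549 cells (Homo sapiens) for inhibition, read by MTT assay, with a stated time of 72 h (on this read-out lower numbers stand for stronger inhibition and higher numbers for weaker inhibition), only two numbers are known, and compound 2 (75700 nM) stands within the scatter of compound 1 (93500 nM). Compound 3 keeps the core of compound 2 and changes one substituent: bromo in place of fluoro on an aromatic carbon. In plain terms, this is bromo in place of fluoro on an aromatic carbon, para to a large group.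

Going by the values given here, one measured step bears on this change. It touches the same place on the ring, with fluoro in place of methoxy on an aromatic carbon, and it lies within the scatter (a 1.2-fold lower number from compound 1 to compound 2 (0.09 log units; within the scatter)). Among the compounds with values here, a single step is thin evidence, and no measured compound yet carries bromo. Even so, that step gives no reason to expect a shift beyond the scatter in this assay, in either direction. The expected change is therefore small (a 1.1-fold lower number from compound 2 to compound 3 (0.03 log units; within the scatter)). Compound 3 is estimated at 70000 nM (expected range 35000 nM to 130000 nM).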

Compound 3, half-maximal inhibitory concentration: 123000 nM
Estimate against measurement, compound 3: 1.8-fold (0.24 log units) below; measured number inside the range.
By their numbers in this assay, from the lowest: compounds 2, 1 and 3 (each within the scatter of the next).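

In this assay the change from 4-fluorophenyl to 4-bromophenyl adds a third substituent at this place on the aromatic ring, and the step stays within the usual scatter (a 1.6-fold higher number from compound 2 to compound 3 (0.21 log units; within the scatter)). The bromo compound is just as hard to tell apart from the methoxy compound (a 1.3-fold higher number from compound 1 to compound 3 (0.12 log units; within the scatter)), so methoxy, fluoro and bromo, each on an aromatic carbon para to a large group, give numbers that this read-out does not separate, and the earlier pair alone could not show that for a third group. Nothing available accounts for why these three substituents read alike, and no cause can be offered for these small steps.

From the compounds shown here alone, with only three substituents at one place on an otherwise shared structure, it remains open whether an amine, a carboxylic acid or a nitrile at this place would give a step beyond the scatter. For the compounds shown here, it also remains open whether any change away from this ring, such as a longer chain in place of the one that all three compounds share, would move the number at all.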